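Chain shortening on the shared core, next cut

The compounds below may be only part of what the source reports. "The series", "measured", "known", "first", "only" and "open" are said of these compounds alone.

Compound 1, `CCCCCCCNc1cnc(C(=O)NCc2ccccc2)cn1`: in an ADME assay on HeLa cells (Homo sapiens) for cytotoxicity, read by microscopy, with a stated time of 6 days (on this read-out lower numbers stand for higher toxicity in this test and higher numbers for lower toxicity in this test), compound 1 gives > 100000 nM, a limit of the assay.
Compound 2, `CCCCCCNc1cnc(C(=O)NCc2ccccc2)cn1`: in this assay compound 2 gives > 100000 nM, a limit of the assay.
Compound 3, `CCCCCCNc1cncc(C(=O)NCc2ccccc2)n1`: in this assay compound 3 gives > 100000 nM, a limit of the assay.

Compound 3 stands at the limit, as do the other two measured compounds; every value shown sits at the limit of > 100000 nM in this assay, at which 3 of the 3 values shown sit, and no numbered reading exists in the set. Compound 4, `CCCCCNc1cncc(C(=O)NCc2ccccc2)n1`, differs from compound 3 by hydrogen in place of methyl on a saturated chain carbon, five bonds along the chain from a nitrogen on an aromatic ring. Within the data shown here, the one measured step of the same kind is a step that the two limits leave unreadable from compound 1 to compound 2, which runs between two limits and gives no readable size. Nothing in the data shows that taking one carbon off the chain moves the read-out, and nothing shows that it does not. The step to compound 4 is therefore expected to stay within the scatter, with a reading of the limit again as the likeliest outcome.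

The step from compound 3 to compound 4 is expected as a step that the limit leaves unreadable from compound 3 to compound 4. Compound 4 is estimated at 150000 nM, in the range 60000 nM to 400000 nM.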

Compound 4, minimum cytotoxic concentration: > 100000 nM
Compound 4 gave a limit, no number; the forecaster's own chance of this, stated with the estimate: 85%; the middle value does not contradict the limit.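

Compound 3 and compound 4 both read as limits, not numbers, in this assay, and the step between them cannot be read. The compounds shown leave open whether chain length on the shared core moves this read-out at all, since every value stands at one limit: the limit of > 100000 nM in this assay, at which 4 of the 4 values shown sit.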